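From nitro to methylamino: an antiproliferative estimate

The compounds below may be only part of what the source reports. "The series", "measured", "known", "first", "only" and "open" are said of these compounds alone.

Measured in a functional assay on A549 cells (Homo sapiens) for antiproliferative activity, read by MTT assay, with a stated time of 72 h; on this read-out higher numbers stand for weaker inhibition of growth and lower numbers for stronger inhibition of growth:
Compound 1 `CC(=O)Nc1cc(OCc2ccccc2)nc(SCc2ccccc2)n1` gives 35200 nM
Compound 2 `COc1cc(OC)n2cc(-c3ccc([N+](=O)[O-])cc3)nc2n1` gives 36600 nM

Only these two compounds have been measured so far. Compound 2, at 36600 nM, lies within the usual scatter of compound 1, so the two cannot be ranked against each other, although their structures differ widely.

Compound 3 `CNc1ccc(-c2cn3c(OC)cc(OC)nc3n2)cc1` keeps the core of compound 2 and carries methylamino in place of nitro on an aromatic carbon, on a six-membered aromatic ring of carbon only, para to a large group: methylamino in place of nitro on an aromatic carbon. Going by the values given here, no measured pair shows what a change of this kind does in this assay, so the expectation rests mainly on the level of compound 2 at 36600 nM. A small move toward stronger inhibition of growth is expected, not clearly beyond the scatter. The expected step is a 1.8-fold lower number from compound 2 to compound 3 (0.26 log units; within the scatter). Compound 3 is estimated at 20000 nM, with an expected range from 6000 nM to 50000 nM.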

Compound 3, concentration for 50% growth inhibition: > 100000 nM
Compound 3 was reported as a limit; the forecaster's own chance of this, stated with the estimate: 15%; middle value at least 5.0-fold (0.69 log units) from the limit.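

In this assay compound 3 is reported only as a limit, > 100000 nM, and not as a measured number. Methylamino in place of nitro on an aromatic carbon, para to a large group, gives an at least 2.7-fold higher number from compound 2 to compound 3 (0.43 log units; beyond the scatter), which is a move toward weaker inhibition of growth and shows that, on the core of compound 2, this position is not indifferent to the group it carries. Compound 3 is the only compound shown that stands at a limit: the limit of > 100000 nM in this assay, at which 1 of the 3 values shown sits.

As far as these compounds go, a single pair does not tell whether the shift comes from nitro leaving or from methylamino entering, and the full size of the step remains unknown. From the compounds shown here alone, how an unsubstituted amine, a dimethylamino group or a nitrile at the same place would read in this assay also stays open, as does whether the same change would have a comparable effect on a different core, such as that of compound 1.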